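Swapping the Urea Aryl Group: Dichloro to Dimethoxy

A few compounds are considered here, and "the series" means these few. Any claim that something is new, unique, unknown or untested is made for them only; others in the source may bear on it.

Compound 1 `COc1cc(NC(=O)Nc2cc(Nc3cc(F)ccc3OC)ncn2)cc(OC)c1`: 42.1%
Compound 2 `COc1cc(Br)ccc1Nc1cc(NC(=O)Nc2c(Cl)cccc2Cl)ncn1`: 47.3%

Of the compounds shown here, two have been measured in a functional assay on NCI-H1581 cells (Homo sapiens) for inhibition, read by MTT assay, with a stated time of 48 h, tested at 10 uM; a lower number here means less inhibition, a higher number more inhibition at the concentration tested (going by the name of the read-out). Compound 1 gives 42.1% and compound 2 gives 47.3%; these two numbers lie within the scatter of each other, so neither can be called stronger.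

Compound 3 `COc1cc(NC(=O)Nc2cc(Nc3ccc(Br)cc3OC)ncn2)cc(OC)c1` has not been measured. Its difference from compound 2 is 3,5-dimethoxyphenyl in place of 2,6-dichlorophenyl on an amide-type nitrogen.

The same 3,5-dimethoxyphenyl group is found in compound 1, whose 42.1% is close to that of compound 2, so the step of a number 3.3 percentage points lower from compound 2 to compound 3 (within the scatter) is expected to stay within the scatter, in no clear direction. Compound 3 is therefore estimated at 44%, with a likely range from 26% to 62%.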

Compound 3, a percentage reported as inhibition, at one concentration (the size of the read-out at that concentration, not a potency): 20.1%
Compound 3: middle estimate off by 23.9 percentage points, on the high side; the measured number lies below the stated range.
By their numbers in this assay, from the lowest: compound 3; then compounds 1 and 2 (each within the scatter of the next).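

In this assay, the 3,5-dimethoxyphenyl group in place of 2,6-dichlorophenyl on the amide-type nitrogen gives a number 27.2 percentage points lower from compound 2 to compound 3 (beyond the scatter), so this position does affect the read-out. The other aryl group matters as well: 4-bromo-2-methoxyphenyl in place of 5-fluoro-2-methoxyphenyl gives a number 22 percentage points lower from compound 1 to compound 3 (beyond the scatter). Nothing available explains either step.

From the compounds shown here alone, it remains open whether the first step would be the same size alongside 5-fluoro-2-methoxyphenyl. Going by these compounds, how a phenyl group carrying an amine or a carboxylic acid would read on the amide-type nitrogen is also open.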